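This account rests on a few compounds, and the source may have more. Where it says the series, first, only, none or still open, it means among the compounds named here.

Measured so far:
compound 1, `Cc1cc(-c2ccccc2C(F)(F)F)cc(C)c1Nc1ccnc(Nc2ccc(C#N)cc2)n1`, gives 4210 nM in an ADME assay on MT4 cells (Homo sapiens) for cytotoxicity, read by MTT assay, with a stated time of 4 days; a lower number here means that less compound is tolerated, a higher number that more compound is tolerated
compound 2, `Cc1cc(-c2cccc(F)c2)cc(C)c1Nc1ccnc(Nc2ccc(C#N)cc2)n1`, gives 4120 nM in this assay

Compound 2 and compound 1 share a core and differ only in the aryl group attached to it; their numbers in this assay sit within the scatter of each other, the step being a 1.0-fold lower number from compound 1 to compound 2 (0.01 log units; within the scatter). Compound 3, `COc1ccc(-c2cc(C)c(Nc3ccnc(Nc4ccc(C#N)cc4)n3)c(C)c2)cc1`, carries a further change at the same position: 4-methoxyphenyl in place of 3-fluorophenyl on an aromatic carbon. Among the compounds with values here, only one measured step bears on this, the one from compound 1 to compound 2, and it was within the scatter even though it too exchanged the aryl group. No other information about this position is at hand. The expectation for compound 3 in this assay is therefore a step of a 1.0-fold lower number from compound 2 to compound 3 (0.00 log units; within the scatter), that is, none beyond the scatter. Compound 3 is estimated at 4100 nM, with a range from 2000 nM to 8500 nM.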

Compound 3, half-maximal cytotoxic concentration: 2890 nM
Estimate against measurement, compound 3: 1.4-fold (0.15 log units) above; the measured number falls inside the stated range.
By their numbers in this assay, from the lowest: compounds 3, 2 and 1 (each within the scatter of the next).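

In this assay the exchange of 3-fluorophenyl for 4-methoxyphenyl gives a 1.4-fold lower number from compound 2 to compound 3 (0.15 log units; within the scatter) and so stays small, even though the entering group carries one hydrogen-bond acceptor and the leaving group carries none. Set against 2-(trifluoromethyl)phenyl, the same group gives a 1.5-fold lower number from compound 1 to compound 3 (0.16 log units; within the scatter) and this places all three aryl groups at this position within the usual scatter of one another. Nothing at hand says why these numbers lie so close together.

As far as these compounds go, all three groups are substituted phenyl rings, so it remains open whether an amine, a carboxylic acid or a longer chain at this position would give a number beyond the scatter. Also open, from the compounds shown here alone, is whether the numbers would stay this close with the nitrile or the two methyl groups replaced, all three compounds having both.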